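Phenylcarbamoyl on the cyclohexyl ring of compound 2

The source may report more compounds than this note shows. Statements on the series, on what has been measured and on what is new or still open speak of the compounds shown alone.

Measured so far:
compound 1, `O=C(/C(=N/O)Nc1ccc(F)c(Br)c1)C1CCN(C(=O)NCc2ccccc2)CC1`, 28 nM
compound 2, `O=C(/C(=N/O)Nc1ccc(F)c(Br)c1)C1CCCCC1`, 63 nM
compound 3, `O=C(/C(=N/O)Nc1ccc(F)c(Br)c1)[C@H]1CC[C@H](NS(=O)(=O)Nc2ccccc2)CC1`, 291 nM

In an assay on tissue (HeLa cells) for inhibition of Indoleamine 2,3-dioxygenase 1 (Homo sapiens), with a stated time of 48 h (on this read-out lower numbers stand for stronger inhibition and higher numbers for weaker inhibition), compound 2 gives 63 nM, the second highest of the three numbers. Compound 1 sits nearest, with a lower number that lies beyond the scatter; compound 3 sits furthest, with a higher number, also beyond the scatter. Compound 4, `O=C(Nc1ccccc1)[C@H]1CC[C@H](C(=O)/C(=N/O)Nc2ccc(F)c(Br)c2)CC1`, has not been measured in this assay. It differs from compound 2 by phenylcarbamoyl in place of hydrogen on a saturated ring carbon. Among the measured compounds, a large group on that ring position is seen both with a lower number, in compound 1 with 28 nM, and with a higher number, in compound 3 with 291 nM, so the direction of the step cannot be read off with confidence. The expected step from compound 2 to compound 4 is a modest fall, a 1.8-fold lower number from compound 2 to compound 4 (0.26 log units; within the scatter), near the edge of the scatter. For compound 4 the estimate in this assay is 35 nM, with a range from 10 nM to 120 nM.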

Compound 4, half-maximal inhibitory concentration: 197 nM
Beside the measured number, compound 4's estimate is 5.6-fold (0.75 log units) below it, outside the stated range (above it).
By their numbers in this assay, from the lowest: compound 1; then compound 2; then compounds 4 and 3 (each within the scatter of the next).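

In this assay, among these compounds, phenylcarbamoyl in place of hydrogen on a saturated ring carbon gives a 3.1-fold higher number from compound 2 to compound 4 (0.50 log units; beyond the scatter) and so provides the first direct reading of a change at this position, as no earlier pair differed in one place. On this evidence, phenylcarbamoyl at this position, three ring bonds from the ring atom that bears a large group, is a step in the unfavourable direction, with hydrogen giving the stronger inhibition of the two. No measured evidence bears on why the step runs this way.

The compounds shown leave open how an amine, a carboxylic acid or a longer chain on that ring carbon would compare with hydrogen. They also leave open whether the other stereoisomer of compound 4 would show the same step.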